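A few compounds are considered here, and "the series" means these few. Any claim that something is new, unique, unknown or untested is made for them only; others in the source may bear on it.

Working notes on the series, read in a functional assay on A549 cells (Homo sapiens) for cytotoxicity, read by MTT assay, with a stated time of 72 h; a lower number here means a stronger inhibitor, a higher number a weaker inhibitor. Compound 1 `CSc1nc(Cl)c(C(=O)c2ccccc2)s1` gives > 100000 nM, which is a limit of the assay and not a number. Among the compounds with values here, compound 2 `CCOC(=O)c1sc(N2CCCC2)nc1Cl` gives 61000 nM, the only actual number so far, so it has no measured neighbour to be ranked against. The next compound to be read is compound 3 `O=C(c1ccccc1)c1sc(N2CCCC2)nc1Cl`, with this change from compound 2: phenyl in place of ethoxy on a carbonyl carbon.

Within the data shown here, no measured step in this assay isolates this change, so its size has to be judged from the two readings alone. Compound 1 also carries phenyl on a carbonyl carbon, and its > 100000 nM is a limit, so a limit reading for compound 3 remains a real possibility. Compound 3 otherwise keeps the rest of compound 2, which reads 61000 nM, and that value anchors the expectation. The estimated step is a 1.2-fold lower number from compound 2 to compound 3 (0.09 log units; within the scatter), which is expected to stay within the scatter, with no firm direction. For compound 3 the expected value is 50000 nM, with an estimated range from 15000 nM to 150000 nM.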

Compound 3, half-maximal inhibitory concentration: 50000 nM
For compound 3 middle estimate and measured number coincide at the digits printed, within the range that was stated.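

Within the data shown here, at the carbonyl carbon, the first step that isolates this change in this assay reads a 1.2-fold lower number from compound 2 to compound 3 (0.09 log units; within the scatter), so ethoxy and phenyl at this place cannot be told apart. The second step, with pyrrolidin-1-yl in place of methylsulfanyl on an aromatic carbon, reads an at least 2.0-fold lower number from compound 1 to compound 3 (0.30 log units; that floor lies within the scatter), which gives only a floor for the size of that change and no measured size. Compound 1 is a limit of the assay and not a number, and the step from it is therefore bounded on one side only: the limit of > 100000 nM in this assay, at which 1 of the 3 values shown sits.

As far as these compounds go, whether an amine, a carboxylic acid or a longer alkyl chain on the carbonyl carbon would separate from phenyl and ethoxy stays open, as does the effect of a piperidine or a morpholine ring in place of pyrrolidin-1-yl on the aromatic carbon. Also open, from the compounds shown here alone, is whether any change on the shared core reaches a reading beyond the scatter from compound 2, which gives 61000 nM.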